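Removing a Methoxy Group from a Pyrazole Thiourea Series

This account rests on a few compounds, and the source may have more. Where it says the series, first, only, none or still open, it means among the compounds named here.

Of the compounds shown here, three share a core and have been tested in a functional assay on MCF7 cells (Homo sapiens) for inhibition, read by CCK-8 assay, with a stated time of 48 h; on this read-out lower numbers stand for stronger inhibition and higher numbers for weaker inhibition. Compound 1 `O=C(NC(=S)Nc1ccc(F)cc1)c1cn(-c2ccccc2)nc1-c1ccccc1` gives 6820 nM. Compound 2 `COc1ccc(-c2nn(-c3ccccc3)cc2C(=O)NC(=S)Nc2ccc(F)cc2)cc1` gives 4990 nM. Compound 3 `COc1ccc(-c2nn(-c3ccccc3)cc2C(=O)NC(=S)Nc2ccc(Cl)cc2)cc1` gives 4760 nM. Compound 2 and compound 3 differ only in the change (chloro in place of fluoro on an aromatic carbon), and that step was a 1.0-fold lower number from compound 2 to compound 3 (0.02 log units; within the scatter). Compound 2 and compound 1 differ in the change (hydrogen in place of methoxy on an aromatic carbon), which made a 1.4-fold higher number from compound 2 to compound 1 (0.14 log units; within the scatter).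

Compound 4 `O=C(NC(=S)Nc1ccc(Cl)cc1)c1cn(-c2ccccc2)nc1-c1ccccc1` has not been measured. It differs from compound 3 by hydrogen in place of methoxy on an aromatic carbon, the same change as between compound 2 and compound 1, at a place described in the same words. Because that earlier step was a 1.4-fold higher number from compound 2 to compound 1 (0.14 log units; within the scatter), the step from compound 3 to compound 4 is expected to be about a 1.4-fold higher number from compound 3 to compound 4 (0.14 log units; within the scatter). Compound 4 is therefore estimated at 6500 nM, most likely between 3500 nM and 12000 nM.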

Compound 4, half-maximal inhibitory concentration: 6230 nM
Beside the measured number, compound 4's estimate is 1.0-fold (0.02 log units) above it; measured number inside the range.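

In this assay, going from 4-methoxyphenyl to phenyl gives a 1.3-fold higher number from compound 3 to compound 4 (0.12 log units; within the scatter), and chloro in place of fluoro gives a 1.1-fold lower number from compound 1 to compound 4 (0.04 log units; within the scatter). Removing the methoxy reads alike on the two cores: the same change on two cores in this assay, a 1.4-fold higher number (0.14 log units; within the scatter) from compound 2 to compound 1 and a 1.3-fold higher number (0.12 log units; within the scatter) from compound 3 to compound 4, 1.0-fold (0.02 log units) apart, within the scatter of two such steps. Every one of these steps lies within the scatter, so the match shows only that neither change made a readable difference on either core, not that a real effect carries from one core to the other, and the chloro for fluoro swap reads the same way: the same change on two cores in this assay, a 1.0-fold lower number (0.02 log units; within the scatter) from compound 2 to compound 3 and a 1.1-fold lower number (0.04 log units; within the scatter) from compound 1 to compound 4, 1.0-fold (0.02 log units) apart, within the scatter of two such steps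

Still open, from the compounds shown here alone, is whether an amine or a carboxylic acid in place of the methoxy would give a step beyond the scatter. The same question stands for a nitrile or a trifluoromethyl group in place of the fluoro or chloro.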